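The compounds below may be only part of what the source reports. "The series", "measured", "known", "first", "only" and "open" are said of these compounds alone.

Compound 1 `O=C(NC(=S)N1CCc2c(OCCCCCOc3ccc(Cl)cc3)cccc21)c1ccco1` gives 4620 nM in an ADME assay on Huh-7 cells (Homo sapiens) for cytotoxicity; a lower number here means that less compound is tolerated, a higher number that more compound is tolerated. Compound 2 `O=C(NC(=S)N1CCc2c(OCCCCCOc3ccc(Cl)cc3)cccc21)c1ccoc1` gives 20100 nM. Compound 3 `O=C(NC(=S)N1CCc2c(OCCCCCOc3ccc(Cl)cc3)cccc21)c1cccs1` gives 10700 nM. Compound 4 `O=C(NC(=S)N1CCc2c(OCCCCCOc3ccc(Cl)cc3)cccc21)c1ccsc1` is not yet measured.

Among the three measured compounds, compound 3 stands second highest; its nearest neighbour is compound 2 (a 1.9-fold lower number from compound 2 to compound 3 (0.27 log units; within the scatter)), its furthest is compound 1 (a 2.3-fold higher number from compound 1 to compound 3 (0.36 log units; beyond the scatter)). The change to compound 4 is thiophen-3-yl in place of thiophen-2-yl on a carbonyl carbon. The step that bears on it most closely is the matching shift in the furan pair, a 4.4-fold higher number from compound 1 to compound 2 (0.64 log units; beyond the scatter), a modest rise. On that ground a rise of similar size is expected for compound 4, a 2.1-fold higher number from compound 3 to compound 4 (0.31 log units; beyond the scatter). Compound 4 is therefore estimated at 22000 nM, with a range from 9000 nM to 55000 nM.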

Compound 4, half-maximal cytotoxic concentration: > 50000 nM
Compound 4 ended at the assay's limit; the forecaster's own chance of this, stated with the estimate: 10%; middle value at least 2.2-fold (0.35 log units) away from the limit.
By their numbers in this assay, from the lowest: compound 1; then compounds 3 and 2 (each within the scatter of the next). At a limit, above all of these: compound 4.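

In this assay, thiophen-3-yl in place of thiophen-2-yl on a carbonyl carbon gives an at least 4.6-fold higher number from compound 3 to compound 4 (0.66 log units; beyond the scatter), so the rise seen in the furan pair recurs in the thiophene pair, with no exception among these compounds. Against the furan compounds, the change gives an at least 2.4-fold higher number from compound 2 to compound 4 (0.39 log units; beyond the scatter) and an at least 10-fold higher number from compound 1 to compound 4 (1.03 log units; beyond the scatter). Compound 4 sits at a limit of the assay: the limit of > 50000 nM in this assay, at which 1 of the 4 values shown sits.

From the compounds shown here alone, how far compound 4 lies past that limit remains unknown. Also open, going by these compounds, is whether the same shift holds for a pyridine ring on this carbonyl.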